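The source may hold more compounds than are shown below. What is called first, only, known or untested is meant among the compounds shown, and "the series" means these compounds.

Measured so far in a functional assay on MCF7 cells (Homo sapiens) for antiproliferative activity, read by CCK-8 assay, with a stated time of 48 h; a lower number here means a stronger inhibitor, a higher number a weaker inhibitor: compound 1 `Cc1cc(Nc2cc(N3CCN(C)CC3)nc(Nc3ccc(F)cc3)n2)n[nH]1` gives 873 nM; compound 2 `COc1ccc(Nc2nc(Nc3cc(C)[nH]n3)cc(N3CCN(C)CC3)n2)cc1OC` gives 6540 nM.

Compound 2 stands highest of the two, its nearest neighbour being compound 1, separated by the step of a 7.5-fold higher number from compound 1 to compound 2 (0.87 log units; beyond the scatter). Compound 3 `Cc1cc(Nc2cc(N3CCN(C)CC3)nc(Nc3ccc(Cl)c(F)c3)n2)n[nH]1` differs from compound 2 by 4-chloro-3-fluorophenyl in place of 3,4-dimethoxyphenyl on a nitrogen on an aromatic ring. Within the data shown here, the single step that bears on this change, a 7.5-fold higher number from compound 1 to compound 2 (0.87 log units; beyond the scatter), went in the opposite direction when 4-fluorophenyl gave way to 3,4-dimethoxyphenyl; returning to a halogen-substituted phenyl, 4-chloro-3-fluorophenyl, is therefore expected to bring the number back down by about the same amount, an 8.2-fold lower number from compound 2 to compound 3 (0.91 log units; beyond the scatter). Compound 3 is estimated at 800 nM, in the range 250 nM to 3000 nM.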

Compound 3, half-maximal inhibitory concentration: 818 nM
Beside the measured number, compound 3's estimate is 1.0-fold (0.01 log units) below it; the range from low to high includes it.
By their numbers in this assay, from the lowest: compounds 3 and 1 (each within the scatter of the next); then compound 2.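

In this assay, 4-chloro-3-fluorophenyl in place of 3,4-dimethoxyphenyl on the nitrogen gives a step beyond the scatter (an 8.0-fold lower number from compound 2 to compound 3 (0.90 log units; beyond the scatter)), so the higher number of compound 2 now stands apart from two halogen-bearing phenyl groups rather than one. The two halogen-bearing groups cannot be told apart at this position (a 1.1-fold lower number from compound 1 to compound 3 (0.03 log units; within the scatter)), a step within the scatter. Nothing available explains either step.

On these data alone, it remains open whether a phenyl with a single methoxy group would side with compound 2 or with the halogen-bearing pair. An unsubstituted phenyl or one carrying a carboxylic acid also remains untested among the compounds shown here.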